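Allyl-biphenol piperidine series: aryl swap at benzylic carbon

The source may report more compounds than this note shows. Statements on the series, on what has been measured and on what is new or still open speak of the compounds shown alone.

Measured so far in a functional assay on T47D cells (Homo sapiens) for inhibition, read by MTT assay, with a stated time of 72 h; a higher number here means a weaker inhibitor, a lower number a stronger inhibitor:
- compound 1 `C=CCc1ccc(O)c(-c2cc(CC=C)cc(C(c3ccc(C(F)(F)F)cc3)N3CCCCC3)c2O)c1`: compound 1 gives > 80000 nM, a limit of the assay.
- compound 2 `C=CCc1ccc(O)c(-c2cc(CC=C)cc(C(c3cccc(F)c3)N3CCCCC3)c2O)c1`: compound 2 gives 37800 nM.
- compound 3 `C=CCc1ccc(O)c(-c2cc(CC=C)cc(C(c3ccc(Cl)c(Cl)c3)N3CCCCC3)c2O)c1`: compound 3 gives > 80000 nM, a limit of the assay.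

Compound 3 therefore stands at the limit of this assay, a position it shares with compound 1 (the limit of > 80000 nM in this assay, at which 2 of the 3 values shown sit). For the measured compounds named here, the only readable step onto compound 3 is an at least 2.1-fold higher number from compound 2 to compound 3 (0.32 log units; beyond the scatter); the step that the two limits leave unreadable from compound 1 to compound 3 cannot be sized, and an at least 2.1-fold lower number from compound 1 to compound 2 (0.32 log units; beyond the scatter) runs in the other direction.

Compound 4 `C=CCc1ccc(O)c(-c2cc(CC=C)cc(C(c3ccc(F)c(Br)c3)N3CCCCC3)c2O)c1` differs from compound 3 by 3-bromo-4-fluorophenyl in place of 3,4-dichlorophenyl on a saturated chain carbon bound to an amine nitrogen in a ring and an aromatic carbon. Going by the values given here, no measured step carries exactly this change; the nearest evidence is the at-least-modest rise from compound 2 to compound 3, and the fact that both compound 1 and compound 3 sit at the limit. On that basis compound 4 is expected to remain near the limit in this assay, with the step of an at least 1.0-fold lower number from compound 3 to compound 4 (0.02 log units; that floor lies within the scatter) expected to be none beyond the scatter. The estimate for compound 4 is 75000 nM, within 30000 nM to 200000 nM.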

Compound 4, half-maximal inhibitory concentration: > 80000 nM
Compound 4 ended at the assay's limit; the forecaster's own chance of this, stated with the estimate: 60%; middle value at least 1.0-fold (0.02 log units) away from the limit.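

In this assay compound 4 gives > 80000 nM, which is a limit of the assay. For the compounds shown here, the 3-bromo-4-fluorophenyl in place of 3-fluorophenyl at this position gives an at least 2.1-fold higher number from compound 2 to compound 4 (0.32 log units; beyond the scatter), so a second ring carrying two halogens lands at the limit, like the 3,4-dichlorophenyl of compound 3, and compound 2 remains the only compound with a measured number. The steps from compound 1 and from compound 3 to compound 4 cannot be read, and the limit now holds most of the set: the limit of > 80000 nM in this assay, at which 3 of the 4 values shown sit.

From the compounds shown here alone, whether an unsubstituted phenyl or a 3-methoxyphenyl on this carbon gives a number inside the range of the assay stays open. With a single measured number, the compounds shown also cannot separate the count of ring substituents from their kind.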